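This account rests on a few compounds, and the source may have more. Where it says the series, first, only, none or still open, it means among the compounds named here.

Compound 1 `CCCCNC(=O)Oc1ccc(Cl)cc1C(=O)Nc1ccc(Cl)c(Cl)c1` and compound 2 `CCCCCNC(=O)Oc1ccc(Cl)cc1C(=O)Nc1ccc(Cl)c(Cl)c1` share one core; in a physicochemical assay for lipophilicity (on this read-out lower numbers stand for lower lipophilicity and higher numbers for higher lipophilicity), compound 1 gives 5.25 and compound 2 gives 5.67. The change between them is methyl in place of hydrogen on a saturated chain carbon, four bonds along the chain from an amide-type nitrogen, and it made a number 0.42 log units higher from compound 1 to compound 2 (beyond the scatter). Compound 3 `CCCCCCCCNC(=O)Oc1ccc(Cl)cc1C(=O)Nc1ccc(Cl)cc1` carries a different core; the difference between the two cores is not broken down here. In this assay compound 3 gives 6.36, the highest of the three, and the gaps to compound 2 and compound 1 lie beyond the scatter. Compound 4 `CCCCCCCCCNC(=O)Oc1ccc(Cl)cc1C(=O)Nc1ccc(Cl)cc1` differs from compound 3 by methyl in place of hydrogen on a saturated chain carbon, eight bonds along the chain from an amide-type nitrogen. This is the same kind of change as from compound 1 to compound 2, though the place differs: four bonds along the chain from an amide-type nitrogen there, eight bonds here. The step of a number 0.44 log units higher from compound 3 to compound 4 (beyond the scatter) is expected, resting on a number 0.42 log units higher from compound 1 to compound 2 (beyond the scatter). Compound 4 is estimated at 6.8, between 6.4 and 7.2.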

Compound 4, partition coefficient: 6.78
Compound 4: the middle estimate sits 0.02 log units above what was measured; measured number inside the range.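

In this assay the change gave a number 0.42 log units higher from compound 3 to compound 4 (beyond the scatter) on the core of compound 3 and a number 0.42 log units higher from compound 1 to compound 2 (beyond the scatter) on the core of compound 1, so in this one comparison the step carried from one core to the other at the same printed size. Among the compounds shown here, only two pairs support this, and the core and the place differ together, four bonds along the chain from an amide-type nitrogen in one pair and eight bonds in the other, so neither factor is isolated and nothing follows for other cores or places. Nothing shown bears on why the two steps agree.

Going by these compounds, whether an amine or a carboxylic acid in place of the methyl would give a comparable step remains open. Also open, on these data alone, is whether a longer chain would continue the same step on either core.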